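The source may hold more compounds than are shown below. What is called first, only, known or untested is meant among the compounds shown, and "the series" means these compounds.

Going by the values given here, in a functional assay on A549 cells (Homo sapiens) for antiproliferative activity, read by sulforhodamine B assay, with a stated time of 48 h (a lower number here means a stronger inhibitor, a higher number a weaker inhibitor), compound 2 `COc1ccc(/C=C/C(=O)C(=Cc2ccc(O)c(F)c2)C(=O)/C=C/c2ccc(OC)cc2OC)c(OC)c1` gives 2070 nM, the higher of the two numbers so far. Compound 1 `COc1ccc(OC)c(/C=C/C(=O)C(=Cc2ccc(O)c(OC)c2)C(=O)/C=C/c2cc(OC)ccc2OC)c1` gives 190 nM, a gap beyond the scatter, but these two differ in more than one place. Compound 3 `COc1ccc(/C=C/C(=O)C(=Cc2ccc(OC)c(O)c2)C(=O)/C=C/c2ccc(OC)cc2OC)c(OC)c1` has 3-hydroxy-4-methoxyphenyl in place of 3-fluoro-4-hydroxyphenyl on a double-bonded chain carbon bound to a double-bonded chain carbon. Among the compounds with values here, no measured single-place step exists as a guide, so compound 1, at 190 nM, offers the only hint, pointing toward a lower number. The estimated step, a moderate one, runs a 3.5-fold lower number from compound 2 to compound 3 (0.54 log units; beyond the scatter). Compound 3 is expected at 600 nM, within an estimated range of 150 nM to 2400 nM.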

Compound 3, half-maximal inhibitory concentration: 380 nM
Estimate against measurement, compound 3: 1.6-fold (0.20 log units) above; the measured number falls inside the stated range.
By their numbers in this assay, from the lowest: compounds 1 and 3 (each within the scatter of the next); then compound 2.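

In this assay, 3-hydroxy-4-methoxyphenyl in place of 3-fluoro-4-hydroxyphenyl on a double-bonded chain carbon bound to a double-bonded chain carbon gives a 5.4-fold lower number from compound 2 to compound 3 (0.74 log units; beyond the scatter) in a single change. This first single-place step shows that the groups on this aromatic ring can move the number beyond the scatter. Nothing available explains the shift.

The two groups differ in more than one way, so the step cannot show which difference matters. As far as these compounds go, how an amine or a carboxylic acid on this ring would read also remains open.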